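A few compounds are considered here, and "the series" means these few. Any claim that something is new, unique, unknown or untested is made for them only; others in the source may bear on it.

Compound 3 `CSc1nonc1/C(=N/O)Nc1ccc(F)c(Br)c1` gives 560 nM in an assay for inhibition of Indoleamine 2,3-dioxygenase 1 (Homo sapiens), read by fluorescence, with a stated time of 1 h (on this read-out lower numbers stand for stronger inhibition and higher numbers for weaker inhibition), the highest of the three numbers seen here. Compound 1 `COc1nonc1/C(=N/O)Nc1ccc(F)c(Br)c1` gives 230 nM, and compound 2 `NS(=O)(=O)NCCSc1nonc1/C(=N/O)Nc1ccc(F)c(Br)c1` gives 130 nM. The untested compound 4 `NS(=O)(=O)NCCOc1nonc1/C(=N/O)Nc1ccc(F)c(Br)c1` differs from compound 3 by 2-(sulfamoylamino)ethoxy in place of methylsulfanyl on an aromatic carbon. Among the compounds with values here, two measured steps bear on this change: a 2.4-fold higher number from compound 1 to compound 3 (0.39 log units; beyond the scatter), and a 1.8-fold lower number from compound 1 to compound 2 (0.25 log units; within the scatter); taken together they appear as a 4.3-fold higher number from compound 2 to compound 3 (0.63 log units; beyond the scatter). Compound 4 combines the oxygen attachment seen in compound 1 with the sulfamoylamino chain seen in compound 2, so a modest fall in the number is expected in this assay, roughly the sum of those two earlier steps. Compound 4 is therefore estimated at 120 nM, with a range from 50 nM to 300 nM. For compound 4 this estimate means an expected 4.7-fold lower number from compound 3 to compound 4 (0.67 log units; beyond the scatter).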

Compound 4, half-maximal inhibitory concentration: 150 nM
For compound 4 the middle estimate is 1.3-fold (0.10 log units) below the measured one; the measured number falls inside the stated range.
By their numbers in this assay, from the lowest: compounds 2, 4 and 1 (each within the scatter of the next); then compound 3.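

In this assay, the step of a 3.7-fold lower number from compound 3 to compound 4 (0.57 log units; beyond the scatter) shows that 2-(sulfamoylamino)ethoxy at this position gives a clearly lower number than methylsulfanyl, whereas oxygen and sulfur attachments of the full chain stay within the scatter, at a 1.2-fold higher number from compound 2 to compound 4 (0.06 log units; within the scatter). On the oxygen attachment, the sulfamoylamino extension also stays within the scatter, at a 1.5-fold lower number from compound 1 to compound 4 (0.19 log units; within the scatter). Removing the extension therefore does not count the same on both attachments: the same change on two cores in this assay, a 4.3-fold higher number (0.63 log units; beyond the scatter) from compound 2 to compound 3 and a 1.5-fold higher number (0.19 log units; within the scatter) from compound 4 to compound 1, 2.8-fold (0.45 log units) apart, beyond the scatter of two such steps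

The compounds shown leave open whether an amine or a carboxylic acid in place of the sulfamoylamino group would hold these numbers. They also leave open what a longer chain would do on either attachment.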